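Aryl hydrazone series: methyl position on the phenyl ring

The source may hold more compounds than are shown below. What is called first, only, known or untested is meant among the compounds shown, and "the series" means these compounds.

Measured so far:
compound 1 `CC1CC/C(=N\Nc2ccc(O)cc2)c2ncc(C(=O)O)c(=O)n21`: > 100 umol/kg
compound 2 `Cc1ccccc1N/N=C1\CCC(C)n2c1ncc(C(=O)O)c2=O`: > 100 umol/kg

In a functional assay on the whole organism for inhibition, with Rattus norvegicus as the target (on this read-out higher numbers stand for an effect only at larger amounts of compound and lower numbers for an effect already at smaller amounts), compound 1 reaches only the limit > 100 umol/kg. Compound 2 likewise stops at the limit > 100 umol/kg in this assay. For the measured compounds named here, the step that the two limits leave unreadable from compound 1 to compound 2 is therefore not readable, and the only evidence on the measured pair is the limit of > 100 umol/kg in this assay, at which 2 of the 2 values shown sit.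

Compound 3 `Cc1cccc(N/N=C2\CCC(C)n3c2ncc(C(=O)O)c3=O)c1` is the next member: 3-methylphenyl in place of 2-methylphenyl on an amine nitrogen. Going by the values given here, no measured step bears on this change, since both values shown are limits and give no size. Compound 3 is therefore expected to sit at the same limit in this assay, with an estimated value of 150 umol/kg in a range from 50 umol/kg to 500 umol/kg. The expected step that the limit leaves unreadable from compound 2 to compound 3 is none beyond the scatter.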

Compound 3, dose for 50% inhibition: 72.5 umol/kg
Compound 3: the middle estimate sits 2.1-fold (0.32 log units) above what was measured; the measured number falls inside the stated range.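

In this assay, for the compounds shown here, compound 3 is the first member of the series to give a number rather than a limit: 72.5 umol/kg. On the amine nitrogen, 3-methylphenyl in place of 2-methylphenyl gives an at least 1.3-fold lower number from compound 2 to compound 3 (0.13 log units; that floor lies within the scatter), and 3-methylphenyl in place of 4-hydroxyphenyl gives an at least 1.3-fold lower number from compound 1 to compound 3 (0.13 log units; that floor lies within the scatter). Both steps are floors, so the change of methyl position yields a readable value but no firm size for either step, and the rest of the series stays at the assay limit: the limit of > 100 umol/kg in this assay, at which 2 of the 3 values shown sit.

From the compounds shown here alone, it remains open how 4-methylphenyl or unsubstituted phenyl would read on the same amine nitrogen with the shared core unchanged. Going by these compounds, it is also open whether another group at that position of the ring, such as 3-chlorophenyl or 3-methoxyphenyl, would give a number like that of compound 3.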